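This account rests on a few compounds, and the source may have more. Where it says the series, first, only, none or still open, it means among the compounds named here.

Compound 1 `COc1cc(/C=C/C(=O)Nc2ccccc2)ccc1OCCCN(C)C` gives 1.55 in a physicochemical assay for lipophilicity, using the shake flask method, measured as octanol-water partition, at pH 7.4; on this read-out lower numbers stand for lower lipophilicity and higher numbers for higher lipophilicity. Compound 2 `COc1cc(/C=C/C(=O)Nc2ccccc2)ccc1OCCCN1CCCC1` gives 1.57. Compound 3 `COc1cc(/C=C/C(=O)Nc2ccccc2)ccc1OCCCCN(C)C` gives 1.57.

Compound 3 stands level with compound 2, the two together the highest of the three numbers, and the gap a number 0.02 log units higher from compound 1 to compound 3 (within the scatter) sits within the scatter, as does no change at the digits printed from compound 2 to compound 3 (within the scatter). Compound 4 `COc1cc(/C=C/C(=O)Nc2ccccc2)ccc1OCCCCN1CCCCC1` carries the change (piperidin-1-yl in place of dimethylamino on a saturated chain carbon, four bonds along the chain from an oxygen on an aromatic ring). Within the data shown here, two measured steps bear on it: the ring closure a number 0.02 log units higher from compound 1 to compound 2 (within the scatter) and the chain extension a number 0.02 log units higher from compound 1 to compound 3 (within the scatter), both within the scatter. On that basis the step of a number 0.18 log units higher from compound 3 to compound 4 (within the scatter) is expected to be small, at most a slight rise beyond what was seen so far. Compound 4 is therefore estimated at 1.75, in a range from 1.45 to 2.1.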

Compound 4, partition coefficient: 1.61
Compound 4: middle estimate off by 0.14 log units, on the high side, and the stated range covers the measured number.
By their numbers in this assay, from the lowest: compounds 1, 2, 3 and 4 (each within the scatter of the next).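

In this assay, piperidin-1-yl in place of dimethylamino, four bonds along the chain from an oxygen on an aromatic ring, gives a number 0.04 log units higher from compound 3 to compound 4 (within the scatter), so this six-membered ring leaves the read-out within the scatter at this position. The comparisons with the amines three bonds along the chain read the same: a number 0.04 log units higher from compound 2 to compound 4 (within the scatter) and a number 0.06 log units higher from compound 1 to compound 4 (within the scatter). Nothing measured here offers an explanation for this result. The compounds shown leave open whether a morpholine ring, a carboxylic acid or a longer chain at this position would move the number beyond the scatter.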